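The source may hold more compounds than are shown below. What is called first, only, known or untested is meant among the compounds shown, and "the series" means these compounds.

Measured compounds:
Compound 1, `N[C@@H](CC1CCCCC1)CN(C(=O)[C@@H]1C[C@H]1c1ccccc1)c1ccc(-c2ccccc2)cc1`: 1.7 nM
Compound 2, `CC(C)CCNCCN(C(=O)[C@@H]1C[C@H]1c1ccccc1)c1ccc(-c2ccccc2)cc1`: 5.1 nM
Compound 3, `CC[C@H](C)[C@H](N)CN(C(=O)[C@@H]1C[C@H]1c1ccccc1F)c1ccc(-c2ccccc2)cc1`: 650 nM

In a functional assay for agonist activity at G protein-coupled receptor 88 (Homo sapiens), read by HTRF and cAMP accumulation (a higher number here means that more compound is needed for the effect, a lower number that less compound is needed), compound 3 gives the highest of the three numbers; compound 2 sits far below it and compound 1 further still, both gaps beyond the scatter. Compound 4, `CC[C@H](C)[C@H](N)CN(C(=O)[C@@H]1C[C@H]1c1ncccn1)c1ccc(-c2ccccc2)cc1`, is the unmeasured partner of compound 3; the difference between them is pyrimidin-2-yl in place of 2-fluorophenyl on a saturated ring carbon. Going by the values given here, the only step measured here is a 3.0-fold higher number from compound 1 to compound 2 (0.48 log units; beyond the scatter), and it concerns the chain carbon bound to the amide-type nitrogen, not the aromatic group on the three-membered ring, so no measured step bears directly on the change from compound 3 to compound 4. With nothing to anchor the direction, the expected step of a 1.4-fold higher number from compound 3 to compound 4 (0.14 log units; within the scatter) is taken as small, possibly toward a higher number, and the range is kept wide. Compound 4 is therefore estimated at 900 nM in this assay, between 200 nM and 4000 nM.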

Compound 4, half-maximal effective concentration: 130 nM
Estimate against measurement, compound 4: 6.9-fold (0.84 log units) above; measured number below the stated range.
By their numbers in this assay, from the lowest: compound 1; then compound 2; then compound 4; then compound 3.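

In this assay, the aromatic group on the three-membered ring proves able to move the number on its own: pyrimidin-2-yl in place of 2-fluorophenyl gives a 5.0-fold lower number from compound 3 to compound 4 (0.70 log units; beyond the scatter) and is the only step shown at this position. The earlier step concerned the chain carbon bound to the amide-type nitrogen, so it said nothing about this ring carbon; here, a ring of carbon only with a fluorine gives way to a ring with two nitrogens, and the number falls. No measurement shown gives a reason for this step.

Still open, on these data alone, is whether the step follows the loss of the fluorine or the entry of the ring nitrogens, which a plain phenyl or a pyridin-2-yl group at this place would help to separate. Also open, as far as these compounds go, is whether pyrimidin-2-yl acts alike with the amine chain of compound 1.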